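Three Anilides at the Limit, a Fourth to Test

The compounds below may be only part of what the source reports. "The series", "measured", "known", "first", "only" and "open" are said of these compounds alone.

Compound 1, `Cc1ccc(C)c(NC(=O)CSc2nnc(-c3ccoc3C)n2Cc2ccco2)c1`: > 15800 nM, a limit
Compound 2, `Cc1cccc(NC(=O)CSc2nnc(-c3ccoc3C)n2Cc2ccco2)c1C`: > 15800 nM, a limit
Compound 3, `COc1ccccc1NC(=O)CSc1nnc(-c2ccoc2C)n1Cc1ccco1`: > 15800 nM, a limit

In a functional assay on CHO cells for antagonist activity at Orexin/Hypocretin receptor type 1 (Homo sapiens), read by FLIPR and calcium flux (a lower number here means a stronger inhibitor, a higher number a weaker inhibitor), compound 2 gives > 15800 nM, which is a limit of the assay and not a number. The same holds for compound 1 and for compound 3, so that (the limit of > 15800 nM in this assay, at which 3 of the 3 values shown sit). Because of this, the step that the two limits leave unreadable from compound 1 to compound 2 cannot be read, nor can a step that the two limits leave unreadable from compound 1 to compound 3 or a step that the two limits leave unreadable from compound 2 to compound 3; none of the three changes on the amide-type nitrogen moved any compound into the readable range of this assay.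

Compound 4, `COc1ccc(NC(=O)CSc2nnc(-c3ccoc3C)n2Cc2ccco2)cc1`, continues from compound 2 with the change (4-methoxyphenyl in place of 2,3-dimethylphenyl on an amide-type nitrogen). The three measured steps bear on it only in that they show this position tolerating two dimethylphenyl groups and a methoxyphenyl group without a readable gain. No step beyond the scatter is therefore expected in this assay, and compound 4 is expected to sit again at the limit, estimated at 20000 nM with a range from 6000 nM to 80000 nM, corresponding to an estimated step that the limit leaves unreadable from compound 2 to compound 4.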

Compound 4, inhibition constant: > 15800 nM
Compound 4: only a limit was reported; the forecaster's own chance of this, stated with the estimate: 85%; the middle value lies beyond the limit too.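

In this assay compound 4 gives > 15800 nM, which is a limit and not a number. Its steps from compound 1, compound 2 and compound 3 therefore cannot be read: the limit of > 15800 nM in this assay, at which 4 of the 4 values shown sit.

The compounds shown leave open whether any other group on the amide-type nitrogen would give a readable value in this assay.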